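The compounds below may be only part of what the source reports. "The series", "measured", "known", "first", "only" and "open" are said of these compounds alone.

The series varies the length of the chain that carries the hydroxycarbamoyl group and the aryl group on the shared core. Compound 1 `Nc1ncnc2c1c(-c1cnc3[nH]ccc3c1)nn2CCCC(=O)NO` has the shortest chain. In a functional assay on HCT-116 cells (Homo sapiens) for inhibition, read by MTT assay, with a stated time of 72 h (a higher number here means a weaker inhibitor, a lower number a stronger inhibitor), compound 1 reaches only the limit of > 150000 nM, a limit and not a number. Compound 3 `Nc1ncnc2c1c(-c1cnc3[nH]ccc3c1)nn2CCCCCCCCC(=O)NO` carries a longer chain; in this assay compound 3 gives 5460 nM, so that an at least 27-fold lower number from compound 1 to compound 3 (1.43 log units; beyond the scatter). Compound 2 `Nc1nc2cc(-c3nn(CCCCCC(=O)NO)c4ncnc(N)c34)ccc2o1` bears a different aryl group and a chain of intermediate length. In this assay compound 2 gives 21500 nM, the highest of the two numbers measured, with compound 3 the nearest value.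

Compound 4 `Nc1nc2cc(-c3nn(CCCC(=O)NO)c4ncnc(N)c34)ccc2o1` awaits measurement. It differs from compound 2 in one place: hydroxycarbamoyl in place of 2-(hydroxycarbamoyl)ethyl on a saturated chain carbon, three bonds along the chain from an aromatic nitrogen. Among the compounds with values here, this shortening runs in the direction opposite to the single measured step, an at least 27-fold lower number from compound 1 to compound 3 (1.43 log units; beyond the scatter), which was large. A shortening of the chain is therefore expected to raise the number in this assay well beyond the scatter. The expected step is a 5.6-fold higher number from compound 2 to compound 4 (0.75 log units; beyond the scatter). For compound 4 the estimated result in this assay is 120000 nM, within 30000 nM to 400000 nM, with a real chance that only a limit is reported, as it was for compound 1 at the limit of > 150000 nM in this assay, at which 1 of the 3 values shown sits.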

Compound 4, half-maximal inhibitory concentration: 19600 nM
Beside the measured number, compound 4's estimate is 6.1-fold (0.79 log units) above it, and the stated range ends above it.
By their numbers in this assay, from the lowest: compound 3; then compounds 4 and 2 (each within the scatter of the next). At a limit, above all of these: compound 1.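

In this assay, shortening the chain on the aryl group of compound 2 leaves no difference that can be read: a 1.1-fold lower number from compound 2 to compound 4 (0.04 log units; within the scatter). Within the data shown here, on this aryl group, then, 5-(hydroxycarbamoyl)pentyl and 3-(hydroxycarbamoyl)propyl cannot be told apart, whereas the only earlier step in chain length, made with the other aryl group and over a longer stretch of chain, was large: an at least 27-fold lower number from compound 1 to compound 3 (1.43 log units; beyond the scatter). Compound 1, which carries the same 3-(hydroxycarbamoyl)propyl chain as compound 4 but the other aryl group, stands at a limit and not at a number: the limit of > 150000 nM in this assay, at which 1 of the 4 values shown sits.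

The compounds shown leave open whether the aryl group of compound 2 would give a lower number with a longer chain like that of compound 3, and how 5-(hydroxycarbamoyl)pentyl would read on the aryl group of compound 1. They also leave open how a carboxylic acid in place of hydroxycarbamoyl at the end of the chain would read on either aryl group.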